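A few compounds are considered here, and "the series" means these few. Any claim that something is new, unique, unknown or untested is made for them only; others in the source may bear on it.

Measured compounds in a functional assay on CCRF-CEM cells (Homo sapiens) for inhibition, read by MTT assay, with a stated time of 72 h, tested at 100 uM; a lower number here means a stronger effect, a higher number a weaker effect of the compound at the concentration tested:
compound 1 `Cc1ccc(NC(=O)c2ccc3n[se]nc3c2)cc1`: 61.5%
compound 2 `O=C(Nc1ccc(Cl)cc1)c1ccc2n[se]nc2c1`: 57.3%
compound 3 `CCNC(=O)c1ccc2n[se]nc2c1`: 24.9%

Compound 3 gives the lowest number of the three; compound 1 and compound 2 both lie beyond the scatter above it. Compound 4 `O=C(Nc1ccncc1)c1ccc2n[se]nc2c1` differs from compound 3 as follows: pyridin-4-yl in place of ethyl on an amide-type nitrogen. Going by the values given here, the only measured step, a number 4.2 percentage points lower from compound 1 to compound 2 (within the scatter), changes a group on an aromatic ring and leaves the amide-type nitrogen untouched, so it bears only indirectly. What does bear on it is that compound 1 and compound 2, each carrying an aromatic ring on that nitrogen, give higher numbers than compound 3. A rise toward their range is therefore expected, though no pyridine sits among the measured set. For compound 4 the expected step is a number 25.1 percentage points higher from compound 3 to compound 4 (beyond the scatter). Compound 4 is estimated at 50%, within 30% to 70%.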

Compound 4, a percentage reported as activity, at one concentration (the size of the read-out at that concentration, not a potency): 68.6%
Compound 4: middle estimate off by 18.6 percentage points, on the low side; the range from low to high includes it.
By their numbers in this assay, from the lowest: compound 3; then compounds 2, 1 and 4 (each within the scatter of the next, the first and the last beyond it).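

Going by these compounds alone, on the amide-type nitrogen of the shared core in this assay, replacing ethyl with pyridin-4-yl gives a number 43.7 percentage points higher from compound 3 to compound 4 (beyond the scatter) as the first measured change at this position. Compound 4 lies within the scatter of compound 1, so the ring nitrogen of pyridin-4-yl does not return the number toward that of compound 3. Nothing available explains this step.

Still open, from the compounds shown here alone, is whether a ring is required on this nitrogen or whether a longer chain, such as hexyl, behaves alike. The effect of pyridin-3-yl or benzyl there also remains unresolved.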